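The compounds below may be only part of what the source reports. "The series", "measured", "known", "first", "only" and "open" are said of these compounds alone.

Compound 1 `CCOC(=O)C1=C(C)OC2OC(COCc3ccccc3)C(OCc3ccccc3)C(OCc3ccccc3)C2S1`: 12600 nM
Compound 2 `CCOC(=O)C1=C(C)OC2OC(COCc3ccccc3)C(OCc3ccccc3)C(OCc3ccccc3)C2[S+]1[O-]`: 250 nM
Compound 3 `CCOC(=O)C1=C(C)OC2OC(COCc3ccccc3)C(O)C(OCc3ccccc3)C2[S+]1[O-]`: a limit, > 10000 nM

In an assay on CHO cells for displacement of a labelled ligand from Substance-K receptor (Homo sapiens) (a higher number here means a weaker inhibitor, a lower number a stronger inhibitor), compound 1 gives 12600 nM, while compound 2 gives 250 nM, a lower number. How the core of compound 1 differs from the core of compound 2 is not broken down here. Compound 3 gives only > 10000 nM, which is a limit of this assay and not a number.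

The change from compound 2 to compound 3 is hydrogen in place of benzyl on an oxygen on a saturated carbon, and it brought an at least 40-fold higher number from compound 2 to compound 3 (1.60 log units; beyond the scatter). Compound 4 `CCOC(=O)C1=C(C)OC2OC(CO)C(OCc3ccccc3)C(OCc3ccccc3)C2S1`, not yet measured, arises from compound 1 by hydrogen in place of benzyl on an oxygen on a saturated carbon. The place is not the same: in compound 2 the oxygen sits on a saturated carbon whose other neighbours are a saturated ring carbon, in compound 1 on one whose other neighbours are a saturated chain carbon, so this is the same kind of change rather than the same change.

Compound 4 is expected to give 150000 nM in this assay, with a range from 15000 nM to 1500000 nM. This expected step, a 12-fold higher number from compound 1 to compound 4 (1.08 log units; beyond the scatter), rests on an at least 40-fold higher number from compound 2 to compound 3 (1.60 log units; beyond the scatter). Compound 1 already gives 12600 nM in this assay. Such a step is expected to carry compound 4 past (the limit of > 10000 nM in this assay, at which 1 of the 3 values shown sits), so compound 4 is expected to return only a limit.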

Compound 4, inhibition constant: 4000 nM
Compound 4: the middle estimate sits 38-fold (1.57 log units) above what was measured; the measured number lies below the stated range.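

In this assay, hydrogen in place of benzyl on an oxygen on a saturated carbon gave a 3.2-fold lower number from compound 1 to compound 4 (0.50 log units; beyond the scatter). The same kind of change therefore does not carry over from one core to the other in this series, and here even its direction reverses: the same change on two cores in this assay, an at least 40-fold higher number (1.60 log units; beyond the scatter) from compound 2 to compound 3 and a 3.2-fold lower number (0.50 log units; beyond the scatter) from compound 1 to compound 4, at least 120-fold (2.10 log units) apart, beyond the scatter of two such steps What this does not show is the reason, since the two steps differ in the core and also in the place of the oxygen, on a saturated carbon whose other neighbours are a saturated chain carbon in one step and a saturated ring carbon in the other, and the pair cannot separate these two differences.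

The compounds shown leave open how the change at the chain carbon would behave on the core of compound 2, and how the change at the ring carbon would behave on the core of compound 1. They also leave open what an amine or a carboxylic acid would do in place of the hydroxy group of compound 4.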